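Swapping the benzamide aryl group in a sulfonamide series

This account rests on a few compounds, and the source may have more. Where it says the series, first, only, none or still open, it means among the compounds named here.

Compound 1 `O=C(NCc1ccc(CNS(=O)(=O)c2ccccc2)cc1)c1ccc(F)cc1` stands highest of the three measured numbers in an assay on MDA-MB-231 cells for binding affinity to C-X-C chemokine receptor type 4 (Homo sapiens), read by immunofluorescence and microscopy, with stated times of 10 min and 30 min (a higher number here means that more compound is needed for the effect, a lower number that less compound is needed), giving 100 nM. Among the compounds with values here, compound 2 `Cc1ccc(S(=O)(=O)NCc2ccc(CNC(=O)c3ccc(Cl)cc3)cc2)cc1` gives 10 nM in this assay, and compound 3 `Cc1ccc(S(=O)(=O)NCc2ccc(CNC(=O)c3ccncc3)cc2)cc1` gives 10 nM; the one measured step, no change at the digits printed from compound 2 to compound 3 (within the scatter), replaces one aryl group on the carbonyl carbon with another and stays within the scatter. Compound 4 `COc1cccc(C(=O)NCc2ccc(CNS(=O)(=O)c3ccccc3)cc2)c1` differs from compound 1 by 3-methoxyphenyl in place of 4-fluorophenyl on a carbonyl carbon. Within the data shown here, that change sits at the same carbonyl carbon as the measured step, which is the only guide available, so no step beyond the scatter is expected in this assay. Compound 4 is therefore estimated at 100 nM, between 30 nM and 300 nM, a step of no change at the digits printed from compound 1 to compound 4 (within the scatter) that is expected to remain within the scatter.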

Compound 4, effective concentration (reported as EC, without a stated level of effect): > 1000 nM
Compound 4: a limit, no number (the forecaster's own chance of this, stated with the estimate: 5%); middle value at least 10-fold (1.00 log units) from the limit.
By their numbers in this assay, from the lowest: compounds 2 and 3 (each within the scatter of the next); then compound 1. At a limit, above all of these: compound 4.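

The carbonyl carbon is not indifferent to its aryl group: 3-methoxyphenyl in place of 4-fluorophenyl gives an at least 10-fold higher number from compound 1 to compound 4 (1.00 log units; beyond the scatter) in this assay, a shift the earlier step, no change at the digits printed from compound 2 to compound 3 (within the scatter), gave no sign of. The reading for compound 4 is a limit, not a number: the limit of > 1000 nM in this assay, at which 1 of the 4 values shown sits.

The compounds shown leave open how an amine or a carboxylic acid on this aryl ring would read. They also leave open whether 3-methoxyphenyl would produce the same step on the core of compound 2.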